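The source may report more compounds than this note shows. Statements on the series, on what has been measured and on what is new or still open speak of the compounds shown alone.

In an ADME assay on S9 fraction from liver (Rattus norvegicus) for metabolic stability, with a stated time of 1 h (on this read-out lower numbers stand for a less stable compound and higher numbers for a more stable compound), three compounds with a shared core have been measured: compound 1 (`N#Cc1cnc(NCc2cnccc2C(F)(F)F)cc1NC[C@H]1C[C@H](O)C1`) gives 61%, compound 2 (`N#Cc1cnc(NCc2cnccc2C(F)(F)F)cc1NC[C@H]1CC[C@@H](O)CC1`) gives 18%, and compound 3 (`CO[C@H]1CC[C@@H](CNc2cc(NCc3cnccc3C(F)(F)F)ncc2C#N)CC1`) gives 2%, the lowest of the three. Compound 4 (`N#Cc1cnc(NCc2cnccc2C(F)(F)F)cc1N[C@H]1CC[C@@H](C(N)=O)CC1`) is still unmeasured. Its change from compound 3 is 4-carbamoylcyclohexyl in place of (4-methoxycyclohexyl)methyl on a nitrogen on an aromatic ring, on a nitrogen on an aromatic ring. For the measured compounds named here, three measured steps bear on this group: a number 43 percentage points lower from compound 1 to compound 2 (beyond the scatter) and a number 59 percentage points lower from compound 1 to compound 3 (beyond the scatter) were large, while a number 16 percentage points lower from compound 2 to compound 3 (beyond the scatter) was modest. None of them introduces a carbamoyl group, so the size remains uncertain. With so little room below compound 3, a modest rise is expected, a number 20 percentage points higher from compound 3 to compound 4 (beyond the scatter). The estimate for compound 4 is 22%, within 5% to 50%.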

Compound 4, percent of the compound remaining: 30%
Compound 4: the middle estimate sits 8 percentage points below what was measured, and the stated range covers the measured number.
By their numbers in this assay, from the lowest: compound 3; then compound 2; then compound 4; then compound 1.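

In this assay, 4-carbamoylcyclohexyl on the nitrogen on an aromatic ring gives a number 28 percentage points higher from compound 3 to compound 4 (beyond the scatter) and a number 12 percentage points higher from compound 2 to compound 4 (beyond the scatter), so a six-membered ring at this position can reach a higher number than either (4-methoxycyclohexyl)methyl or (4-hydroxycyclohexyl)methyl. Even so, the change gives a number 31 percentage points lower from compound 1 to compound 4 (beyond the scatter), leaving (3-hydroxycyclobutyl)methyl with the highest number of the four. No measurement at hand accounts for these differences. The compounds shown leave open whether the rise comes from the carbamoyl group or from the shorter attachment, since both differ at once. They also leave open how an amine or a carboxylic acid would read on the same cyclohexyl.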